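The source may hold more compounds than are shown below. What is called first, only, known or untested is meant among the compounds shown, and "the series" means these compounds.

In a functional assay on NCI-H1975 cells (Homo sapiens) for inhibition, read by sulforhodamine B assay, tested at 10 uM (a higher number here means more inhibition at the concentration tested (going by the name of the read-out), a lower number less inhibition), the two measured compounds gave these numbers:

Compound 1, `CC(=O)N1N=C(c2ccc(-n3cncn3)cc2)CC1c1ccc(N(C)C)cc1`, gives -0.3%.
Compound 2, `CN(C)c1ccc(C2CC(c3ccc(-n4cncn4)cc3)=NN2C(=O)/C=C/c2ccccc2)cc1`, gives -2.3%.

Compound 2 has the lower of the two numbers, but its number and that of compound 1 lie within the usual scatter of each other, so the two cannot be told apart. Compound 3, `CN(C)c1ccc(C2CC(c3ccc(-n4cncn4)cc3)=NN2S(=O)(=O)c2ccc(Br)cc2)cc1`, has not yet been measured. It differs from compound 2 in one place: (4-bromophenyl)sulfonyl in place of (2-phenylethenyl)carbonyl on an amine nitrogen in a ring. Among the measured compounds shown here, only one measured step bears on this change, a number 2 percentage points lower from compound 1 to compound 2 (within the scatter), which altered the group on the same ring nitrogen and stayed within the scatter. That step kept the carbonyl, whereas the change to compound 3 removes it and brings in a sulfonyl, so the measured step covers the new change only in part. For compound 3 the expected step is a number 2.3 percentage points higher from compound 2 to compound 3 (within the scatter), none beyond the scatter. Compound 3 is therefore estimated at 0%, in the range -15% to 18%.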

Compound 3, a percentage reported as inhibition, at one concentration (the size of the read-out at that concentration, not a potency): -0.6%
The estimate for compound 3 lay 0.6 percentage points above the measured number; the range from low to high includes it.
By their numbers in this assay, from the lowest: compounds 2, 3 and 1 (each within the scatter of the next).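

Replacing the carbonyl link on the ring nitrogen with a sulfonyl link, while the group keeps its aromatic ring, gives no separable result in this assay: the change from (2-phenylethenyl)carbonyl gives a number 1.7 percentage points higher from compound 2 to compound 3 (within the scatter), and the change from acetyl gives a number 0.3 percentage points lower from compound 1 to compound 3 (within the scatter). The position has now carried a small acyl group, a larger acyl group and an arylsulfonyl group, and these three compounds cannot be told apart in this read-out. No available information explains this result.

The compounds shown leave open whether a group of another kind on this nitrogen, such as a carboxylic acid or an amine on a longer chain, would move the number beyond the scatter. They also leave open what replacing the 4-(dimethylamino)phenyl group or the 4-(1H-1,2,4-triazol-1-yl)phenyl group would do.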